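Swapping an Aromatic Ester for a Branched Aliphatic One

This account rests on a few compounds, and the source may have more. Where it says the series, first, only, none or still open, it means among the compounds named here.

Three compounds sharing one core differ only in the ester group attached to it. In a functional assay on A549 cells (Homo sapiens) for cytotoxicity, read by MTT assay, with a stated time of 48 h (a higher number here means a weaker inhibitor, a lower number a stronger inhibitor), compound 2 `C=C1C(=O)O[C@H]2CC3=C[C@H](C/C(C)=C/[C@@H](OC(=O)c4ccc(C(C)=O)cc4)[C@H]12)OC3=O` gives 2300 nM, the lowest of the two numbers measured. Compound 3 `C=C1C(=O)O[C@H]2CC3=C[C@H](C/C(C)=C/[C@@H](OC(=O)/C=C/c4cccc(OC)c4)[C@H]12)OC3=O` gives 6200 nM, and a 2.7-fold higher number from compound 2 to compound 3 (0.43 log units; beyond the scatter). Compound 1 `C=C1C(=O)O[C@H]2CC3=C[C@H](C/C(C)=C/[C@@H](OC(=O)c4ccc(C(F)(F)F)cc4)[C@H]12)OC3=O` reached only a limit of the assay, > 10000 nM. Compound 4 `C=C1C(=O)O[C@H]2CC3=C[C@H](C/C(C)=C/[C@@H](OC(=O)C(C)(C)CC)[C@H]12)OC3=O` carries 1,1-dimethylpropyl in place of 4-acetylphenyl on a carbonyl carbon. For the measured compounds named here, both measured steps kept an aromatic ester: an at least 4.3-fold lower number from compound 1 to compound 2 (0.63 log units; beyond the scatter), while a 2.7-fold higher number from compound 2 to compound 3 (0.43 log units; beyond the scatter), so no measured step resembles losing the ring altogether. Compound 4 is therefore expected to give a somewhat higher number, with a 2.4-fold higher number from compound 2 to compound 4 (0.38 log units; beyond the scatter). The estimate for compound 4 in this assay is 5500 nM, ranging from 2000 nM to 15000 nM.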

Compound 4, half-maximal inhibitory concentration: 2200 nM
For compound 4 the middle estimate is 2.5-fold (0.40 log units) above the measured one, within the range that was stated.
By their numbers in this assay, from the lowest: compounds 4 and 2 (each within the scatter of the next); then compound 3. At a limit, above all of these: compound 1.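

The ring on the ester is not required for this level of activity: 1,1-dimethylpropyl, which has no ring, sits level with 4-acetylphenyl on the same carbonyl carbon (a 1.0-fold lower number from compound 2 to compound 4 (0.02 log units; within the scatter)). It also compares well with the ring-bearing 2-(3-methoxyphenyl)ethenyl (a 2.8-fold lower number from compound 3 to compound 4 (0.45 log units; beyond the scatter)). Against 4-(trifluoromethyl)phenyl the step gives only a floor (an at least 4.5-fold lower number from compound 1 to compound 4 (0.65 log units; beyond the scatter)), as compound 1 stands at a limit rather than a number: the limit of > 10000 nM in this assay, at which 1 of the 4 values shown sits.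

Still open, from the compounds shown here alone, is whether an isopropyl group, a longer straight chain or a chain carrying an amine would hold this level. Nothing shown explains the differences among these esters.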